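Trading an Isopropoxy Ether for a Plain Butyl Chain

The source may report more compounds than this note shows. Statements on the series, on what has been measured and on what is new or still open speak of the compounds shown alone.

Compound 1, `COc1cc(Cc2nc3c(N)nc(F)nc3n2CCOC(C)C)cc(OC)c1OC`, gives 15800 nM in a functional assay on MCF7 cells (Homo sapiens) for antiproliferative activity; on this read-out lower numbers stand for stronger inhibition and higher numbers for weaker inhibition.
Compound 2, `COc1cc(Cc2nc3c(N)nc(F)nc3n2CCOC(C)C)c(Cl)c(OC)c1OC`, gives 5370 nM.
Compound 3, `CCC(C)Cn1c(Cc2cc(OC)c(OC)c(OC)c2)nc2c(N)ncnc21`, gives 61700 nM.

On these numbers compound 1 stands second highest of the three: compound 2 sits below it, as the step of a 2.9-fold lower number from compound 1 to compound 2 (0.47 log units; beyond the scatter) shows, and compound 3 lies above it by more than the usual scatter. Compound 4, `CCCCn1c(Cc2cc(OC)c(OC)c(OC)c2)nc2c(N)nc(F)nc21`, has not yet been measured. It differs from compound 1 in one place: ethyl in place of isopropoxy on a saturated chain carbon, two bonds along the chain from an aromatic nitrogen. Among the measured compounds shown here, no measured step touches this chain directly. For the measured compounds named here, the only step on record, a 2.9-fold lower number from compound 1 to compound 2 (0.47 log units; beyond the scatter), concerns a chloro group on an aromatic carbon and says nothing about the side chain. Compound 3 carries a branched chain and also lacks the fluorine of compound 1, so its higher number cannot be laid on the chain alone. With so little to lean on, the step of a 1.6-fold higher number from compound 1 to compound 4 (0.20 log units; within the scatter) is expected to be small, leaning if anything toward a higher number. Compound 4 is therefore estimated at 25000 nM, within a range from 8000 nM to 80000 nM.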

Compound 4, half-maximal inhibitory concentration: 24000 nM
For compound 4 the middle estimate is 1.0-fold (0.02 log units) above the measured one, and the stated range covers the measured number.
By their numbers in this assay, from the lowest: compound 2; then compounds 1 and 4 (each within the scatter of the next); then compound 3.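

In this assay, among the compounds shown here, the step of a 1.5-fold higher number from compound 1 to compound 4 (0.18 log units; within the scatter) is the first reading at this place on the chain. It shows that isopropoxy, with its oxygen, can give way to ethyl without a difference beyond the scatter. Read one bond further out, 2-isopropoxyethyl becomes butyl, so for this pair the ether oxygen in the chain is not needed to keep the number at this level, though no data at hand explain the outcome.

The compounds shown carry only isopropoxy and ethyl at this place, which leaves open how a longer chain, an alcohol or an amine there would read. On these data alone, it also remains open how the chloro group of compound 2 would read when combined with the butyl chain of compound 4.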